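Three Measured Analogues and an Untested Urea-Type Variant

This account rests on a few compounds, and the source may have more. Where it says the series, first, only, none or still open, it means among the compounds named here.

Compound 1, `COc1ccc(C(=O)Nc2ccc3nc(NC(=O)C4CCCCC4)sc3c2)cc1`, gives 4.9 ug/mL in a functional assay on WI-38 VA13 cells (Homo sapiens) for cytotoxicity; a lower number here means that less compound is needed, a higher number that more compound is needed for the effect.
Compound 2, `N#Cc1ccc(C(=O)Nc2ccc3nc(NC(=O)C4CCCCC4)sc3c2)cc1`, gives 3.3 ug/mL.
Compound 3, `CC(=O)Nc1ccc2nc(NC(=O)C3CCCCC3)sc2c1`, gives 2.7 ug/mL.

All three compounds share the same core and differ only in the group attached to one carbonyl carbon. Compound 2 sits between the other two on the numbers shown: the gap a 1.5-fold lower number from compound 1 to compound 2 (0.17 log units; within the scatter) and the gap a 1.2-fold lower number from compound 2 to compound 3 (0.09 log units; within the scatter) are both within the scatter, so no ordering among them can be claimed.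

The untested compound 4, `Cc1cccc(C)c1NC(=O)Nc1ccc2nc(NC(=O)C3CCCCC3)sc2c1`, is obtained from compound 2 by the change ((2,6-dimethylphenyl)amino in place of 4-cyanophenyl on a carbonyl carbon). Among the compounds with values here, no measured step covers this exact change. Within the data shown here, the steps that bear on it are those at the same carbonyl carbon, a 1.8-fold lower number from compound 1 to compound 3 (0.26 log units; within the scatter) and a 1.2-fold lower number from compound 2 to compound 3 (0.09 log units; within the scatter), both within the scatter, suggesting that this position tolerates rather different groups without a step beyond the scatter. The estimated step of no change at the digits printed from compound 2 to compound 4 (within the scatter) is therefore expected to stay within the scatter. Compound 4 is estimated at 3.3 ug/mL, with a range from 1.5 ug/mL to 7.5 ug/mL.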

Compound 4, half-maximal effective concentration: 0.56 ug/mL
Estimate against measurement, compound 4: 5.9-fold (0.77 log units) above; the whole stated range lies above it.
By their numbers in this assay, from the lowest: compound 4; then compounds 3, 2 and 1 (each within the scatter of the next).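

In this assay, the carbonyl carbon turns out to be less tolerant than compound 1, compound 2 and compound 3 had suggested: (2,6-dimethylphenyl)amino in place of 4-cyanophenyl gives a 5.9-fold lower number from compound 2 to compound 4 (0.77 log units; beyond the scatter), a step beyond the scatter. The same group gives a 4.8-fold lower number from compound 3 to compound 4 (0.68 log units; beyond the scatter) in place of methyl and an 8.8-fold lower number from compound 1 to compound 4 (0.94 log units; beyond the scatter) in place of 4-methoxyphenyl, so compound 4 stands apart from all three, and less of it is needed for the effect. Nothing measured here accounts for these steps.

The compounds shown leave open whether the steps belong to the added amino nitrogen or to the two methyl groups: a plain phenylamino group, or 2,6-dimethylphenyl directly on the carbonyl carbon, would separate the two. On these data alone, whether an alkylamino group such as cyclohexylamino would serve equally also remains open.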